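Cytotoxicity notes: piperazine to dimethylaminopiperidine swap

The source may hold more compounds than are shown below. What is called first, only, known or untested is meant among the compounds shown, and "the series" means these compounds.

The series shares one core bearing a basic saturated ring on the aromatic carbon. Going by the values given here, compound 1 `CN1CCN(c2cccn3cc(CN(C)[C@H]4CCCc5cccnc54)nc23)CC1` is one of the two measured members. In an ADME assay on HOS cells (Homo sapiens) for cytotoxicity (on this read-out higher numbers stand for lower toxicity in this test and lower numbers for higher toxicity in this test), compound 1 gives > 5000 nM, which is a limit of the assay rather than a number. Compound 2 `CCN1CCN(c2cccc3nc(CN(C)[C@H]4CCCc5cccnc54)cn23)CC1` is the other measured member. In this assay compound 2 gives 3900 nM, the only number shown in this assay, so compound 2 stands alone as the sole numeric point. Compound 1 sits at the limit (the limit of > 5000 nM in this assay, at which 1 of the 2 values shown sits). Among the compounds with values here, no step between measured compounds can be drawn from these two results, and no direction is established.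

Compound 3 `CN(C)C1CCN(c2cccc3nc(CN(C)[C@H]4CCCc5cccnc54)cn23)CC1` is not yet measured. It differs from compound 2 by 4-(dimethylamino)piperidin-1-yl in place of 4-ethylpiperazin-1-yl on an aromatic carbon. Both groups bring the same count of hydrogen-bond acceptors and carry no net charge. Within the data shown here, because compound 2 gives 3900 nM and the measured data offer no step to guide a direction, the expected step is a 1.2-fold higher number from compound 2 to compound 3 (0.06 log units; within the scatter), none beyond the scatter. Compound 3 is therefore estimated at 4500 nM in this assay, within 2000 nM to 10000 nM.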

Compound 3, half-maximal cytotoxic concentration: 3400 nM
The estimate for compound 3 lay 1.3-fold (0.12 log units) above the measured number, within the range that was stated.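

In this assay, going by these compounds alone, 4-(dimethylamino)piperidin-1-yl in place of 4-ethylpiperazin-1-yl on an aromatic carbon, next to the ring nitrogen, gives a 1.1-fold lower number from compound 2 to compound 3 (0.06 log units; within the scatter); this is the first step that can be read at all. At this position, then, a six-membered non-aromatic ring with 2 hetero atoms and one with 1 hetero atom carrying a dimethylamino group give values within the scatter of each other, so this one change does not separate compound 2 from compound 3 in this read-out. Compound 1 remains a limit of the assay and not a number, and no step to it can be read: the limit of > 5000 nM in this assay, at which 1 of the 3 values shown sits.

From the compounds shown here alone, both groups compared here are saturated rings with no net charge, so it stays open whether a group of another kind on the same aromatic carbon, such as morpholine, a primary amine or a carboxylic acid, would give a step beyond the scatter. With a single step at a single position, the compounds shown also leave open whether the same swap would give a similar result elsewhere on the shared core.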